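Aryl in place of chloro on the shared core

The source may hold more compounds than are shown below. What is called first, only, known or untested is meant among the compounds shown, and "the series" means these compounds.

Measured so far in a physicochemical assay for lipophilicity, read by spectrophotometry, measured as octanol-water partition, at pH 7.4; a higher number here means a more lipophilic compound, a lower number a more polar compound
- compound 1 `CCOc1cc(CN2CCC(NC(=O)c3cncc(C)c3)CC2)cc(OCC)c1-c1ccc(F)cc1` gives 4.01
- compound 2 `CCOc1cc(CN2CCC(NC(=O)c3cncc(C)c3)CC2)cc(OCC)c1Cl` gives 3.43
- compound 3 `CCOc1cc(CN2CCC[C@@H](NC(=O)c3cncc(C)c3)CC2)ccc1Cl` gives "not determined" (no result reported)

Compound 2 holds the lower of the two numbers, at 3.43, while compound 3 offers no number for comparison. The step of interest leads to compound 4 `CCOc1cc(CN2CCC(NC(=O)c3cncc(C)c3)CC2)cc(OCC)c1-c1ccc(OC(F)(F)F)cc1`, and the change is 4-(trifluoromethoxy)phenyl in place of chloro on an aromatic carbon. Within the data shown here, the one measured step that bears on it is a number 0.58 log units lower from compound 1 to compound 2 (beyond the scatter), a modest step beyond the scatter, with chloro in place of 4-fluorophenyl on an aromatic carbon. Compound 4 runs that kind of exchange the other way, with 4-(trifluoromethoxy)phenyl as the entering group rather than the 4-fluorophenyl of compound 1. Among the measured compounds shown here, no measured step separates those two groups, so the size remains uncertain. A rise in this assay of similar or somewhat larger size is therefore expected. The estimated change is a number 0.97 log units higher from compound 2 to compound 4 (beyond the scatter). Compound 4 is expected at 4.4, with an estimated range from 3.95 to 4.9.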

Compound 4, distribution coefficient: > 4
Compound 4 ended at the assay's limit (the forecaster's own chance of this, stated with the estimate: 10%); the middle value does not contradict the limit.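

In this assay compound 4 gives > 4, which is a limit of the assay and not a number. Even so, the exchange at this position, ortho to two ethoxy groups, can be read with a second aryl group: 4-(trifluoromethoxy)phenyl in place of chloro gives a number at least 0.57 log units higher from compound 2 to compound 4 (beyond the scatter), the same direction as the aryl-to-chloro comparison a number 0.58 log units lower from compound 1 to compound 2 (beyond the scatter) implies when read in reverse. The step between the two aryl groups cannot be read, so the change from fluoro to trifluoromethoxy on the entering phenyl gains no size: the limit of > 4 in this assay, at which 1 of the 4 values shown sits.

On these data alone, the order of those two aryl groups in this assay stays open. Also open, as far as these compounds go, is how a phenyl carrying an amine or a carboxylic acid would read at this position.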